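A Pyrazole Swap Expected to Raise Solubility Further

The source may report more compounds than this note shows. Statements on the series, on what has been measured and on what is new or still open speak of the compounds shown alone.

Compound 3 `O=S(=O)(Nc1ccncn1)c1ccc2c(c1)OCC[C@@H]2c1ccc(C(F)(F)F)cc1-c1ccc(F)cn1` gives the highest number in a physicochemical assay for solubility (a higher number here means a more soluble compound, a lower number a less soluble compound), of the three measured compounds, 181000 nM. Compound 2 `O=S(=O)(Nc1nccs1)c1ccc2c(c1)OCC[C@@H]2c1ccc(C(F)(F)F)cc1-c1ccc(F)cn1` gives 7000 nM, and compound 1 `Cn1nccc1-c1cc(C(F)(F)F)ccc1[C@H]1CCOc2cc(S(=O)(=O)Nc3nccs3)ccc21` gives 83000 nM. The cores of compound 2 and compound 3 differ by pyrimidin-4-yl in place of 1,3-thiazol-2-yl on a sulfonamide nitrogen, a change that produced a 26-fold higher number from compound 2 to compound 3 (1.41 log units; beyond the scatter). Compound 4 `Cn1nccc1-c1cc(C(F)(F)F)ccc1[C@H]1CCOc2cc(S(=O)(=O)Nc3ccncn3)ccc21` is not yet measured; it differs from compound 3 by 1-methyl-1H-pyrazol-5-yl in place of 5-fluoropyridin-2-yl on an aromatic carbon. The same change, (1-methyl-1H-pyrazol-5-yl in place of 5-fluoropyridin-2-yl on an aromatic carbon), separates the two measured compounds on the other core, where it gave a 12-fold higher number from compound 2 to compound 1 (1.07 log units; beyond the scatter). Repeating that change, compound 4 is expected to show a 6.6-fold higher number from compound 3 to compound 4 (0.82 log units; beyond the scatter), an expectation that rests on a 12-fold higher number from compound 2 to compound 1 (1.07 log units; beyond the scatter) having been seen once, on a core that differs only in the sulfonamide substituent. Compound 4 is therefore estimated at 1200000 nM, most likely between 350000 nM and 3500000 nM.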

Compound 4, solubility: 1180000 nM
For compound 4 the middle estimate is 1.0-fold (0.01 log units) above the measured one; measured number inside the range.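

In this assay, putting 1-methyl-1H-pyrazol-5-yl in place of 5-fluoropyridin-2-yl gave a 6.5-fold higher number from compound 3 to compound 4 (0.81 log units; beyond the scatter) on the core carrying pyrimidin-4-yl, and the same change gave a 12-fold higher number from compound 2 to compound 1 (1.07 log units; beyond the scatter) on the core carrying 1,3-thiazol-2-yl, so the change carried over between these two cores in direction and in broad size. Pyrimidin-4-yl in place of 1,3-thiazol-2-yl likewise gave a 14-fold higher number from compound 1 to compound 4 (1.15 log units; beyond the scatter) and also a 26-fold higher number from compound 2 to compound 3 (1.41 log units; beyond the scatter) in the same direction. Two cores are too few to make a general rule, and nothing measured here explains the size of either change.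

Still open, as far as these compounds go, is how the number would move with an amine or a carboxylic acid in place of 5-fluoropyridin-2-yl. Also open, from the compounds shown here alone, is whether 1-methyl-1H-pyrazol-5-yl gives a similar step with other groups on the sulfonamide nitrogen.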